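The source may hold more compounds than are shown below. What is called first, only, known or untested is meant among the compounds shown, and "the series" means these compounds.

Of the compounds shown here, three sharing one core have so far been tested in a functional assay on A-375 cells (Homo sapiens) for inhibition, read by CCK-8 assay, with a stated time of 72 h, tested at 2 uM; a higher number here means more inhibition of growth at the concentration tested, a lower number less inhibition of growth. Compound 1 `Cc1ccc(SCc2ccc(/C=C/C(=O)Nc3ccccc3N)cc2)cc1` gives 22.9%. Compound 2 `COc1ccc(SCc2ccc(/C=C/C(=O)Nc3ccccc3N)cc2)cc1OC` gives 46%. Compound 3 `Nc1ccccc1NC(=O)/C=C/c1ccc(CSc2cccc(F)c2)cc1` gives 6.75%, the lowest of the three numbers; both changes leading to it, a number 16.2 percentage points lower from compound 1 to compound 3 (beyond the scatter) and a number 39.3 percentage points lower from compound 2 to compound 3 (beyond the scatter), end at this low value.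

Compound 4 `CCc1ccc(SCc2ccc(/C=C/C(=O)Nc3ccccc3N)cc2)cc1` differs from compound 3 only at the group on the sulfur: 4-ethylphenyl in place of 3-fluorophenyl on a sulfur. Because a number 16.2 percentage points lower from compound 1 to compound 3 (beyond the scatter) describes the reverse of a closely similar change, 4-methylphenyl and 4-ethylphenyl being alike in all but chain length, a modest rise is the most natural expectation. The step of a number 39.3 percentage points lower from compound 2 to compound 3 (beyond the scatter) points the same way, though 3,4-dimethoxyphenyl is less similar to 4-ethylphenyl. The expected step is therefore a number 18.3 percentage points higher from compound 3 to compound 4 (beyond the scatter), a modest gain in growth inhibition. Compound 4 is estimated to give 25%, within a range of 8% to 45%.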

Compound 4, percent growth inhibition at one concentration: 5.27%
Compound 4: the middle estimate sits 19.7 percentage points above what was measured; measured number below the stated range.
By their numbers in this assay, from the lowest: compounds 4 and 3 (each within the scatter of the next); then compound 1; then compound 2.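

In this assay, methyl in place of hydrogen on a saturated chain carbon bound to an aromatic carbon turns 4-methylphenyl into 4-ethylphenyl and brings a number 17.6 percentage points lower from compound 1 to compound 4 (beyond the scatter), so even this small extension of the group on the sulfur changes the result. Two different groups on the sulfur, 4-ethylphenyl and 3-fluorophenyl, cannot be told apart here, with a number 1.5 percentage points lower from compound 3 to compound 4 (within the scatter), while 3,4-dimethoxyphenyl remains well separated from 4-ethylphenyl, with a number 40.7 percentage points lower from compound 2 to compound 4 (beyond the scatter). No supporting measurement is available to explain these differences.

The compounds shown leave open whether a phenyl ring carrying a single methoxy group would stay close to 3,4-dimethoxyphenyl or fall towards 4-ethylphenyl. They also leave open how an unsubstituted phenyl, a propyl-bearing phenyl or an amino-bearing phenyl on the sulfur would compare.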